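A few compounds are considered here, and "the series" means these few. Any claim that something is new, unique, unknown or untested is made for them only; others in the source may bear on it.

In an ADME assay on HEK293 cells (Homo sapiens) for cytotoxicity, read by MTT assay, with a stated time of 48 h (on this read-out higher numbers stand for weaker inhibition and lower numbers for stronger inhibition), three compounds on a shared core have been measured. Compound 1 `CN(C)CCn1c(N)c(-c2nc3ccccc3[nH]2)c2nc(C#N)c(C#N)nc21` gives 9730 nM, and compound 2 `CN1CCN(CCn2c(N)c(-c3nc4ccccc4[nH]3)c3nc(C#N)c(C#N)nc32)CC1` gives 10900 nM. Compound 3 `N#Cc1nc2c(-c3nc4ccccc4[nH]3)c(N)n(CCO)c2nc1C#N` gives > 50000 nM, which is a limit of the assay and not a number.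

Compound 4 `N#Cc1nc2c(-c3nc4ccccc4[nH]3)c(N)n(CCCN3CCCCC3)c2nc1C#N` departs from compound 3 at one place: (piperidin-1-yl)methyl in place of hydroxy on a saturated chain carbon, two bonds along the chain from an aromatic nitrogen. Here (piperidin-1-yl)methyl stands in place of hydroxy on a saturated chain carbon, two bonds along the chain from an aromatic nitrogen, turning 2-hydroxyethyl into 3-(piperidin-1-yl)propyl.

The closest measured changes run the opposite way, ending in the hydroxy of compound 3: an at least 5.1-fold higher number from compound 1 to compound 3 (0.71 log units; beyond the scatter) and an at least 4.5-fold higher number from compound 2 to compound 3 (0.66 log units; beyond the scatter). Exchanging dimethylamino for 4-methylpiperazin-1-yl gave only a 1.1-fold higher number from compound 1 to compound 2 (0.05 log units; within the scatter). Going by the values given here, no measured compound carries the 3-(piperidin-1-yl)propyl chain, so the reversal is an imperfect guide. A move to a lower number in this assay is nevertheless expected, at least modest in size, and the expected step is an at least 5.8-fold lower number from compound 3 to compound 4 (0.76 log units; beyond the scatter). Compound 4 is estimated at 8500 nM, with an expected range of 3000 nM to 22000 nM.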

Compound 4, half-maximal inhibitory concentration: 6720 nM
Estimate against measurement, compound 4: 1.3-fold (0.10 log units) above; the measured number falls inside the stated range.
By their numbers in this assay, from the lowest: compounds 4, 1 and 2 (each within the scatter of the next). At a limit, above all of these: compound 3.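

In this assay, replacing the hydroxy of the 2-hydroxyethyl chain with the (piperidin-1-yl)methyl of the 3-(piperidin-1-yl)propyl chain gives an at least 7.4-fold lower number from compound 3 to compound 4 (0.87 log units; beyond the scatter), a step that can be read only as a bound. The longer chain with its six-membered non-aromatic ring does not set compound 4 apart from the two shorter amine chains, with a 1.6-fold lower number from compound 2 to compound 4 (0.21 log units; within the scatter) and a 1.4-fold lower number from compound 1 to compound 4 (0.16 log units; within the scatter). Among the four compounds, the position thus tolerates three different amine groups without a step beyond the scatter, while compound 3 stands alone at a limit of the assay, which is not a number: the limit of > 50000 nM in this assay, at which 1 of the 4 values shown sits.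

Compound 4 alone carries the longer chain, so the effect of chain length remains unseparated from that of the piperidin-1-yl ring. As far as these compounds go, a 2-(piperidin-1-yl)ethyl chain, a 3-hydroxypropyl chain, a morpholine or a carboxylic acid at this position remains open.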